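Trifluoromethyl for Chloro in a Histamine Agonist Series

The source may report more compounds than this note shows. Statements on the series, on what has been measured and on what is new or still open speak of the compounds shown alone.

Compound 1 `N=C(NCCCc1c[nH]cn1)NCCSC(c1ccccc1)c1ccccn1` and compound 2 `N=C(NCCCc1c[nH]cn1)NCCC(c1ccc(Cl)cc1)c1ccccn1` share a common core. In a functional assay on cardiac atrium for agonist activity at histamine H2 receptor (Cavia porcellus) (a lower number here means a less potent compound, a higher number a more potent compound, by a factor of ten per unit of this negative logarithm), compound 1 gives 6.6, and compound 2 gives 7.84. Of the two measured compounds, compound 2 stands highest, its number lying beyond the scatter above that of compound 1. Compound 3 `N=C(NCCCc1c[nH]cn1)NCCC(c1ccc(C(F)(F)F)cc1)c1ccccn1` differs from compound 2 by trifluoromethyl in place of chloro on an aromatic carbon. For the measured compounds named here, no comparable step between measured compounds is at hand. The author expects the step of a number 0.14 log units lower from compound 2 to compound 3 (within the scatter) to stay within the scatter, in no clear direction. Compound 3 is therefore estimated at 7.7, with a range from 7.1 to 8.3.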

Compound 3, negative logarithm of the half-maximal effective concentration: 7.76
Beside the measured number, compound 3's estimate is 0.06 log units below it, within the range that was stated.
By their numbers in this assay, from the lowest: compound 1; then compounds 3 and 2 (each within the scatter of the next).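

In this assay the change from 4-chlorophenyl to 4-(trifluoromethyl)phenyl gives a number 0.08 log units lower from compound 2 to compound 3 (within the scatter) even though 1 heavy atom gives way to 4 heavy atoms, so this place on the aromatic ring takes either group without a readable change. The earlier compounds shown here offered no such step at this position. Nothing at hand bears on why the two groups read alike. The compounds shown leave open whether this tolerance extends beyond these two groups, for instance to an amine, a carboxylic acid or a methoxy group at the same place.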